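The source may hold more compounds than are shown below. What is called first, only, known or untested is meant among the compounds shown, and "the series" means these compounds.

For the measured compounds named here, in an ADME assay on MT4 cells (Homo sapiens) for cytotoxicity, with a stated time of 5 days (a lower number here means that less compound is tolerated, a higher number that more compound is tolerated), only two compounds carry a number so far. Compound 1 (`CC(C)(C)C#Cc1cc(N(C(=O)[C@H]2CC[C@H](C)CC2)[C@H]2CC[C@H](OC3COC3)CC2)c(C(=O)O)s1`) gives 8350 nM, the lower of the two, and compound 2 (`CC(C)(C)C#Cc1cc(N(C(=O)[C@H]2CC[C@H](C)CC2)[C@H]2CC[C@@](O)(CO[C@H]3CCOC3)CC2)c(C(=O)O)s1`) gives 18100 nM, a gap just beyond the usual scatter. Going by the values given here, no step with a single change has been measured, so nothing yet calibrates the next comparison.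

Compound 3 (`CC(C)(C)C#Cc1cc(N(C(=O)[C@H]2CC[C@H](C)CC2)[C@H]2CC[C@H](Oc3ccccn3)CC2)c(C(=O)O)s1`) is unmeasured and departs from compound 1 at one place: pyridin-2-yl in place of oxetan-3-yl on an oxygen on a saturated carbon. In words, this is pyridin-2-yl in place of oxetan-3-yl on an oxygen on a saturated carbon.

Among the compounds with values here, the only direct anchor is compound 1 at 8350 nM, so the expectation stays close to that number. Within the data shown here, it leans slightly downward on judgement alone, as no measured compound carries the pyridin-2-yl group. The estimated change, a 1.4-fold lower number from compound 1 to compound 3 (0.14 log units; within the scatter), is expected to stay within the scatter. For compound 3 the expected value is 6000 nM, with an estimated range of 2500 nM to 14000 nM.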

Compound 3, half-maximal cytotoxic concentration: 100 nM
Estimate against measurement, compound 3: 60-fold (1.78 log units) above; measured number outside the range, below it.
By their numbers in this assay, from the lowest: compound 3; then compound 1; then compound 2.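

In this assay, for the compounds shown here, the group on an oxygen on a saturated carbon proves to be far from neutral: pyridin-2-yl in place of oxetan-3-yl gives an 84-fold lower number from compound 1 to compound 3 (1.92 log units; beyond the scatter) and is the first single-change step that can be read. Less compound is tolerated with the pyridin-2-yl group, even though both groups have the same hydrogen-bond donor and acceptor counts and neither has a net charge, so these counts alone do not flag this change in the series. The groups do differ in ring size, in aromatic versus non-aromatic character and in heavy-atom count, but no measurement available here explains the step or assigns it to any one of these differences.

Going by these compounds alone, the single step cannot separate the contribution of the aromatic ring from that of its ring nitrogen; phenyl, pyridin-3-yl or pyridin-4-yl on the same oxygen would bear directly on that question. Tetrahydropyran-4-yl would test whether a larger saturated ring is tolerated as well as oxetan-3-yl, and it remains open whether the step carries over to other groups elsewhere on the core of compound 1.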